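Hydroxy for Ethyl on a Sulfonamide Nitrogen

The source may hold more compounds than are shown below. What is called first, only, known or untested is meant among the compounds shown, and "the series" means these compounds.

Compound 1 `N=S1(=O)CC(Nc2nonc2/C(=N/O)Nc2ccc(F)c(Br)c2)C1` and compound 2 `CCNS(=O)(=O)CCNc1nonc1/C(=N/O)Nc1ccc(F)c(Br)c1` share the same core and differ in a single group. In an assay on HeLa cells for inhibition of Indoleamine 2,3-dioxygenase 1 (Homo sapiens), read by spectrophotometry, with a stated time of 24 h (on this read-out higher numbers stand for an effect only at larger amounts of compound and lower numbers for an effect already at smaller amounts), compound 1 gives 53 nM, while compound 2 gives 41 nM. Among the measured compounds shown here, the one measured step, a 1.3-fold lower number from compound 1 to compound 2 (0.11 log units; within the scatter), does not separate the two, so compound 2 sits at the lower end of the two numbers without standing apart from compound 1. Compound 3 `O=S(=O)(CCNc1nonc1/C(=N/O)Nc1ccc(F)c(Br)c1)NO` is the next member, and its change from compound 2 reads: hydroxy in place of ethyl on a sulfonamide nitrogen. For the measured compounds named here, no measured step bears directly on a sulfonamide nitrogen; the only step available, a 1.3-fold lower number from compound 1 to compound 2 (0.11 log units; within the scatter), altered another part of the molecule and stayed within the scatter. The expected step, a 1.5-fold higher number from compound 2 to compound 3 (0.17 log units; within the scatter), is therefore estimated to be small. Compound 3 is estimated at 60 nM in this assay, with a range from 20 nM to 180 nM.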

Compound 3, half-maximal effective concentration: > 800 nM
Compound 3 ended at the assay's limit; the forecaster's own chance of this, stated with the estimate: 5%; middle value at least 13-fold (1.12 log units) away from the limit.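

In this assay, compound 3 stands at a limit of the assay and not at a number: the limit of > 800 nM in this assay, at which 1 of the 3 values shown sits.

Hydroxy in place of ethyl on a sulfonamide nitrogen gives an at least 19-fold higher number from compound 2 to compound 3 (1.29 log units; beyond the scatter), and the comparison with the other measured compound reads an at least 15-fold higher number from compound 1 to compound 3 (1.17 log units; beyond the scatter). The earlier compounds shown here had offered only a 1.3-fold lower number from compound 1 to compound 2 (0.11 log units; within the scatter), which left the two undivided, whereas this result shows that a change confined to this one nitrogen can move the read-out well beyond the scatter.

How far compound 3 actually lies past the limit remains unknown, and the compounds shown give no cause for the step. Also open, going by these compounds, is whether a methyl, a methoxy or a plain hydrogen on this sulfonamide nitrogen would stay close to compound 2 or fall with compound 3.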